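Shortening the alkyl chain of compound 2 by one carbon

The compounds below may be only part of what the source reports. "The series", "measured", "known", "first", "only" and "open" are said of these compounds alone.

Among the compounds with values here, compound 2 `CCCCCc1cc2nn(-c3ccccc3)cc2cn1` gives the lowest number of the three compounds measured so far. In a functional assay on MCF7 cells (Homo sapiens) for inhibition, read by fluorescence, with a stated time of 72 h (a higher number here means a weaker inhibitor of growth, a lower number a stronger inhibitor of growth), compound 2 gives 11800 nM. Compound 3 `CCCCc1cc2nn(-c3ccccc3)cc2c(C(C)C)n1` gives 33300 nM, a number beyond the scatter from that of compound 2, and compound 1 `Cc1nc(C2CC2)cc2nn(-c3ccccc3)cc12` gives 63500 nM, further still from compound 2. None of these three pairs differs in only one place, so no single-change step can be read from the measured compounds.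

Compound 4 `CCCCc1cc2nn(-c3ccccc3)cc2cn1` is the next member to be measured in this assay. Its difference from compound 2 is hydrogen in place of methyl on a saturated chain carbon, four bonds along the chain from an aromatic carbon; cut one bond further out the same change reads butyl to propyl. Compound 3 carries the same butyl chain as compound 4 together with a second substituent on the shared core, and compound 3 gives 33300 nM, which gives some support to a weaker number for the shorter chain, though the second substituent in compound 3 leaves this uncertain.

For compound 4 the expected step from compound 2 is a 1.7-fold higher number from compound 2 to compound 4 (0.23 log units; within the scatter), a modest move to a higher number, near the edge of the scatter. Compound 4 is therefore estimated at 20000 nM, with a range from 8000 nM to 50000 nM.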

Compound 4, concentration for 50% growth inhibition: 13300 nM
Estimate against measurement, compound 4: 1.5-fold (0.18 log units) above, within the range that was stated.
By their numbers in this assay, from the lowest: compounds 2 and 4 (each within the scatter of the next); then compounds 3 and 1 (each within the scatter of the next).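

Hydrogen in place of methyl on a saturated chain carbon, four bonds along the chain from an aromatic carbon, leaves the number in this assay within the scatter, with a 1.1-fold higher number from compound 2 to compound 4 (0.05 log units; within the scatter), so this methyl can be lost with no readable change in growth inhibition. Compound 4 also supplies a single-change comparison at a second place: hydrogen in place of isopropyl on an aromatic carbon gives a 2.5-fold lower number from compound 3 to compound 4 (0.40 log units; beyond the scatter), a modest step beyond the scatter, so at that carbon hydrogen goes with the stronger inhibitor of growth and isopropyl with the weaker. No measurement shown here bears on why either step has its size.

Open, going by these compounds, is how far the chain can change before the number moves: a longer chain, a much shorter one such as ethyl, or an amine or a carboxylic acid at the chain end could each give a different reading. On these data alone, at the aromatic carbon, only hydrogen and isopropyl can be compared here, so the effect of a smaller group such as chlorine or methoxy remains unknown.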